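Fluoro to methoxy on the benzoyl ring of compound 2

This account rests on a few compounds, and the source may have more. Where it says the series, first, only, none or still open, it means among the compounds named here.

Within the data shown here, compound 2 `COc1cc(-c2nnc3n2NC(c2cccs2)C(C(=O)c2ccc(F)cc2)S3)cc(OC)c1OC` is the more potent of the two compounds measured so far. In a functional assay on PC-3 cells (Homo sapiens) for cytotoxicity, read by MTT assay, with a stated time of 48 h (on this read-out lower numbers stand for stronger inhibition and higher numbers for weaker inhibition), compound 2 gives 27400 nM, while compound 1 `COc1cc(-c2nnc3n2NC(c2cccs2)C(C(=O)c2ccccc2)S3)cc(OC)c1OC` in this assay gives 86300 nM. Among the measured compounds shown here, the one step measured between them, a 3.1-fold lower number from compound 1 to compound 2 (0.50 log units; beyond the scatter), is the only change recorded at this position.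

Compound 3 `COc1ccc(C(=O)C2Sc3nnc(-c4cc(OC)c(OC)c(OC)c4)n3NC2c2cccs2)cc1` is not yet measured. It differs from compound 2 by methoxy in place of fluoro on an aromatic carbon; the same change read one bond further out is (4-fluorophenyl)carbonyl to (4-methoxyphenyl)carbonyl, on an aromatic carbon of a six-membered aromatic ring of carbon only, para to a large group.

For the measured compounds named here, no measured step swaps fluoro for methoxy, so the step from hydrogen to fluoro is only a loose guide: it showed that a small group at this place moved the number modestly. An exchange of one small group for another at the same place is therefore expected to give no step beyond the scatter, with a slight lean toward a higher number, so the expected step is a 1.3-fold higher number from compound 2 to compound 3 (0.11 log units; within the scatter). Compound 3 is estimated at 35000 nM in this assay, within a range from 12000 nM to 100000 nM.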

Compound 3, half-maximal inhibitory concentration: 95900 nM
Compound 3: middle estimate off by 2.7-fold (0.44 log units), on the low side; the range from low to high includes it.
By their numbers in this assay, from the lowest: compound 2; then compounds 1 and 3 (each within the scatter of the next).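

Fluoro to methoxy at this place, on an aromatic carbon para to a large group, is not a neutral exchange in this assay: it gives a 3.5-fold higher number from compound 2 to compound 3 (0.54 log units; beyond the scatter) and so takes away the gain that fluoro showed over hydrogen. Methoxy in place of hydrogen gives a 1.1-fold higher number from compound 1 to compound 3 (0.05 log units; within the scatter) and thus leaves no measurable difference between those two compounds, so among the three groups tested here, only fluoro stands apart, with compound 2 holding the lowest number. No measurement is available that would account for this separation of fluoro from hydrogen and methoxy.

From the compounds shown here alone, it remains open whether the lower number belongs to fluoro alone or would also appear with chloro, trifluoromethyl or nitrile at this place, and how a hydroxy group or an amine would read out there. All three compounds also share the rest of the core, so the compounds shown cannot tell whether these steps would hold if another part of that core were changed.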